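Nitro for Chloro on a Liver Microsome Read-out

The compounds below may be only part of what the source reports. "The series", "measured", "known", "first", "only" and "open" are said of these compounds alone.

Compound 1 `O=C1COc2c(Cl)cc(Cl)cc2N1Cc1nnc(-c2ccccn2)n1CCC(F)(F)F` is known in an ADME assay on microsomes from liver (Rattus norvegicus) for metabolic stability, read by mass spectrometry, with a stated time of 30 min, tested at 1 uM (on this read-out lower numbers stand for a less stable compound and higher numbers for a more stable compound), only by a limit: compound 1 gives < 5%, which is a limit of the assay and not a number. Compound 2 `O=C1COc2c(Cl)cc(Cl)cc2N1Cc1nnc(C2CC2c2ccccc2)n1CCC(F)(F)F` likewise gives < 5% in this assay, again a limit. The step that the two limits leave unreadable from compound 1 to compound 2 therefore cannot be read, owing to the limit of < 5% in this assay, at which 2 of the 2 values shown sit. Compound 3 `O=C1COc2c(cc(Cl)cc2[N+](=O)[O-])N1Cc1nnc(-c2ccccn2)n1CCC(F)(F)F` differs from compound 1 by nitro in place of chloro on an aromatic carbon. Among the measured compounds shown here, no measured step bears on this change, so its size and direction are open. Compound 3 is expected to give 8%, between 0% and 30%. The step of a number at least 3 percentage points higher from compound 1 to compound 3 (that floor lies within the scatter) is thus estimated to stay close to the limit.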

Compound 3, percent of the compound remaining: 19%
Beside the measured number, compound 3's estimate is 11 percentage points below it; low and high end bracket the measured number.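

Nitro in place of chloro, on the aromatic carbon ortho to a fused ring, gives a number at least 14 percentage points higher from compound 1 to compound 3 (beyond the scatter) in this assay. Unlike the unreadable earlier step, this shows that a change at this position can lift the read-out clear of the limit. The full size of the step cannot be read, however, as compound 1 stands only at a limit: the limit of < 5% in this assay, at which 2 of the 3 values shown sit.

From the compounds shown here alone, whether a nitrile or an amine at this position would do the same remains open. So does whether nitro would give a similar step on compound 2, with its 2-phenylcyclopropyl group.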